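This account rests on a few compounds, and the source may have more. Where it says the series, first, only, none or still open, it means among the compounds named here.

Series notes, an assay on isolated protein for inhibition of serine/threonine-protein kinase D2 (Homo sapiens), read by mobility shift assay, tested at 30 uM; a higher number here means more inhibition at the concentration tested (going by the name of the read-out), a lower number less inhibition.

Of the compounds shown here, three have numbers so far. Compound 1 `Cc1cc2[nH]nc(N)c2c(=O)[nH]1` gives -1%. Compound 2 `Nc1n[nH]c2cc(-c3ccccn3)[nH]c(=O)c12` gives 33%. Compound 3 `Cc1cc2c(c(N)nn2C)c(=O)[nH]1` gives 5%. Within this set compound 3 stands second highest; its nearest neighbour is compound 1, and the one step that separates them, methyl in place of hydrogen on an aromatic nitrogen, is a number 6 percentage points higher from compound 1 to compound 3 (within the scatter), within the scatter. The gap from compound 3 up to compound 2 is beyond the scatter.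

The next compound in the series is compound 4 `Cn1nc(N)c2c(=O)[nH]c(-c3ccccn3)cc21`, which differs from compound 3 by pyridin-2-yl in place of methyl on an aromatic carbon. The entering group brings one six-membered aromatic ring with one hetero atom and one hydrogen-bond acceptor; the leaving group is one carbon.

Within the data shown here, no measured step shows this exact change. The nearest information is the pair compound 1 and compound 2, which carry hydrogen rather than methyl on the aromatic nitrogen and show the same change of group: the values there sit apart by more than the scatter, the pyridin-2-yl compound being the higher. The step from compound 1 to compound 3 shows that the methyl on the aromatic nitrogen itself moved the number little. For compound 4 the step from compound 3 is therefore expected to be upward and beyond the scatter, estimated as a number 31 percentage points higher from compound 3 to compound 4 (beyond the scatter). Compound 4 is thus expected at about 36%, in the range 15% to 58%.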

Compound 4, a percentage reported as inhibition, at one concentration (the size of the read-out at that concentration, not a potency): 17%
Compound 4: the middle estimate sits 19 percentage points above what was measured, within the range that was stated.
By their numbers in this assay, from the lowest: compounds 1 and 3 (each within the scatter of the next); then compound 4; then compound 2.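

In this assay, pyridin-2-yl in place of methyl on the aromatic carbon next to the ring nitrogen still raises the number when methyl sits on the aromatic nitrogen, with the step reading a number 12 percentage points higher from compound 3 to compound 4 (beyond the scatter). Methyl in place of hydrogen on the aromatic nitrogen is also no longer a change without consequence once pyridin-2-yl is present, with the step now reading a number 16 percentage points lower from compound 2 to compound 4 (beyond the scatter). The two changes therefore do not add independently across these four compounds, and the result of the methyl depends on the group carried at the aromatic carbon: the same change on two cores in this assay, a number 6 percentage points higher (within the scatter) from compound 1 to compound 3 and a number 16 percentage points lower (beyond the scatter) from compound 2 to compound 4, 22 percentage points apart, beyond the scatter of two such steps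

Pyridin-2-yl is the only ring shown at this aromatic carbon, so phenyl and pyridin-3-yl would be needed to tell whether the ring itself or the placement of its nitrogen goes with the higher numbers. Hydrogen and methyl are the only groups shown on the aromatic nitrogen, which leaves open whether ethyl or a longer chain there would lower the number further on the pyridin-2-yl core, or leave it unchanged on the core of compound 1.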